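A few compounds are considered here, and "the series" means these few. Any claim that something is new, unique, unknown or untested is made for them only; others in the source may bear on it.

Compound 1 `CC(C)[C@H](NC(=O)COc1cccc2ccccc12)C(=O)N[C@@H](CC(=O)O)C(=O)CSc1nnnn1-c1ccccc1` gives 153000 nM in a functional assay on Jurkat cells (Homo sapiens) for inhibition; a higher number here means a weaker inhibitor, a lower number a stronger inhibitor.
Compound 2 `Cc1cc(OCC(=O)[C@H](CC(=O)O)NC(=O)[C@@H](NC(=O)COc2cccc3ccccc23)C(C)C)nc(C)n1` gives > 200000 nM in this assay, which is a limit of the assay and not a number.

The step of interest runs from compound 2 to compound 3 `CC(C)[C@H](NC(=O)COc1cccc2ccccc12)C(=O)N[C@@H](CC(=O)O)C(=O)COc1cccc2cccnc12`. Compound 2 stands at the edge of what the assay reports: its value is a limit, and it sits at the limit of > 200000 nM in this assay, at which 1 of the 2 values shown sits. The structural change is quinolin-8-yl in place of 2,6-dimethylpyrimidin-4-yl on an oxygen on a saturated carbon. Within the data shown here, only one measured step bears on it, an at least 1.3-fold higher number from compound 1 to compound 2 (0.11 log units; that floor lies within the scatter), where one aryl-bearing group on that chain carbon replaced another and the number moved higher, though the floor of that move lies within the scatter. Both measured compounds are weak, and swapping one aromatic group on the oxygen for another gives no ground to expect a large shift. Compound 3 is expected to remain in the same weak range, so a number no higher from compound 2 to compound 3 (the limit leaves the size open) is expected to be small. Compound 3 is therefore estimated at 200000 nM, between 70000 nM and 600000 nM.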

Compound 3, half-maximal inhibitory concentration: > 200000 nM
Compound 3: no number, only a limit; the forecaster's own chance of this, stated with the estimate: 50%; the middle value sits exactly at the limit.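

Quinolin-8-yl in place of 2,6-dimethylpyrimidin-4-yl on this oxygen gives no readable change, and the step between compound 2 and compound 3 cannot be read, as both end in a limit rather than a number. Among these compounds, the one step that can be read is an at least 1.3-fold higher number from compound 1 to compound 3 (0.11 log units; that floor lies within the scatter), the same reading that the 2,6-dimethylpyrimidin-4-yl group gave against the same starting point. Two different aromatic groups on this oxygen, one with a single ring and one with two, now stand at the same edge of the assay: the limit of > 200000 nM in this assay, at which 2 of the 3 values shown sit.

From the compounds shown here alone, whether a smaller group on this oxygen, such as a plain phenyl or a pyridin-3-yl, would give a readable value remains open. So does whether a methyl ester in place of the carboxylic acid of the shared core would shift the reading in this assay.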